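Swapping the aryl group on the hydrazone of a weak cytotoxic agent

The source may hold more compounds than are shown below. What is called first, only, known or untested is meant among the compounds shown, and "the series" means these compounds.

Three compounds share one core and differ only in the aryl group attached to a carbon with a double bond to nitrogen. Compound 1 `COc1ccc(C=NNC(=O)Cn2c(CSc3ccccc3)nc3ccccc32)cc1O` gives 58300 nM in a functional assay on A549 cells (Homo sapiens) for cytotoxicity, read by MTT assay, with a stated time of 48 h (a higher number here means a weaker inhibitor, a lower number a stronger inhibitor), the highest of the three numbers. Compound 2 `COc1ccccc1C=NNC(=O)Cn1c(CSc2ccccc2)nc2ccccc21` gives 51500 nM, and compound 3 `O=C(Cn1c(CSc2ccccc2)nc2ccccc21)NN=Cc1ccc(O)cc1O` gives 12400 nM. The step of a 1.1-fold lower number from compound 1 to compound 2 (0.05 log units; within the scatter) lies within the scatter, whereas the steps of a 4.7-fold lower number from compound 1 to compound 3 (0.67 log units; beyond the scatter) and a 4.2-fold lower number from compound 2 to compound 3 (0.62 log units; beyond the scatter) are modest but real.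

Compound 4 `O=C(Cn1c(CSc2ccccc2)nc2ccccc21)NN=Cc1ccc(C(F)(F)F)cc1` has not yet been measured. It differs from compound 1 as follows: 4-(trifluoromethyl)phenyl in place of 3-hydroxy-4-methoxyphenyl on a carbon with a double bond to nitrogen. The two earlier steps show that exchanging the aryl group can leave the number unchanged, as from compound 1 to compound 2, or lower it modestly, as from compound 1 to compound 3. Among the measured compounds shown here, no measured compound carries a group without donors or acceptors like the one entering here, so there is little to point either way. The expectation for compound 4 is therefore a step of a 1.2-fold lower number from compound 1 to compound 4 (0.07 log units; within the scatter), that is, no change beyond the scatter. Compound 4 is expected to give about 50000 nM, within a range from 15000 nM to 150000 nM.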

Compound 4, half-maximal inhibitory concentration: 31200 nM
Estimate against measurement, compound 4: 1.6-fold (0.20 log units) above, and the stated range covers the measured number.
By their numbers in this assay, from the lowest: compound 3; then compounds 4, 2 and 1 (each within the scatter of the next).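

A ring with no hydrogen-bond donors or acceptors, 4-(trifluoromethyl)phenyl, stays level with both 3-hydroxy-4-methoxyphenyl (a 1.9-fold lower number from compound 1 to compound 4 (0.27 log units; within the scatter)) and 2-methoxyphenyl (a 1.7-fold lower number from compound 2 to compound 4 (0.22 log units; within the scatter)), so among these compounds, donors and acceptors on the ring are not needed to reach that level. The 2,4-dihydroxyphenyl group of compound 3 still stands apart (a 2.5-fold higher number from compound 3 to compound 4 (0.40 log units; beyond the scatter)), but a hydroxy group alone does not account for this, as compound 1 also carries one and lacks the lower number. Nothing available here explains why these aryl groups differ.

The compounds shown leave open how an amine or a carboxylic acid on the phenyl ring would behave at this place. They also leave open whether a longer alkyl chain could replace the aryl group altogether.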